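A few compounds are considered here, and "the series" means these few. Any claim that something is new, unique, unknown or untested is made for them only; others in the source may bear on it.

Measured compounds in an assay on cells for displacement of a labelled ligand from adenosine receptor A1 (Homo sapiens), read by scintillation counting, with a stated time of 120 min, tested at 1 uM; on this read-out higher numbers stand for more inhibition at the one concentration tested (going by the name of the read-out) and lower numbers for less inhibition:
compound 1 `O=C(Nc1nccn2cc(-c3ccccc3)nc12)c1ccccc1` — 18%
compound 2 `COc1ccc(-c2cn3ccnc(NC(=O)c4ccccc4)c3n2)cc1` — 1%
compound 3 `O=C(Nc1nccn2cc(-c3ccco3)nc12)c1ccccc1` — 7%

Compound 1 gives the highest number of the three. Compound 3 comes nearest, since the change of a number 11 percentage points lower from compound 1 to compound 3 (beyond the scatter) is beyond the scatter, and compound 2 lies furthest, with a number 17 percentage points lower from compound 1 to compound 2 (beyond the scatter). Between the two lower compounds, a number 6 percentage points higher from compound 2 to compound 3 (within the scatter) is within the scatter, so nothing can be said of their order.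

Compound 4 `O=C(Nc1ccccc1)Nc1nccn2cc(-c3ccccc3)nc12` has not yet been measured. It differs from compound 1 by anilino in place of phenyl on a carbonyl carbon. Every measured step concerns the ring attached to the shared core, and none touches the carbonyl carbon that changes here, so the three measured steps bear on this change only indirectly: they show that a modest change away from compound 1 has, in each measured case, lowered the number beyond the scatter. Among the measured compounds shown here, the change in compound 4 is of a different kind, and there is no measured pair that tells its direction. The estimate for compound 4 in this assay is therefore 20%, between 2% and 50%, which means an expected step of a number 2 percentage points higher from compound 1 to compound 4 (within the scatter), a shift that may well fall within the scatter.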

Compound 4, a percentage reported as inhibition, at one concentration (the size of the read-out at that concentration, not a potency): 1%
Beside the measured number, compound 4's estimate is 19 percentage points above it, and the stated range ends above it.
By their numbers in this assay, from the lowest: compounds 2, 4 and 3 (each within the scatter of the next); then compound 1.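

Among the compounds shown here, the first measured change on the carbonyl carbon, anilino in place of phenyl, gives in this assay a number 17 percentage points lower from compound 1 to compound 4 (beyond the scatter). For the compounds shown here, this shows that the number responds to the group on the carbonyl carbon as well as to the ring attached to the shared core, whereas the earlier steps spoke only of that ring. Among the compounds shown, each single change away from compound 1, at either place, has lowered the number beyond the scatter, and nothing here offers an explanation for this new step.

The compounds shown leave open whether the lower number belongs to anilino in particular or would also follow other groups on the carbonyl carbon, such as a benzyl group, a methylamino group or a longer alkyl chain. They also leave open whether anilino would act in the same way with furan-2-yl or 4-methoxyphenyl on the shared core, and, since every number comes from one concentration, how these compounds compare in potency.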